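Benzamide analogue of the neopentyl amide: lipophilicity notes

The compounds below may be only part of what the source reports. "The series", "measured", "known", "first", "only" and "open" are said of these compounds alone.

Measured compounds:
compound 1 `Cc1cc(C(=O)Nc2cccc(F)c2)nn1Cc1cc(Cl)ccc1OCc1ccccc1` — 2.8
compound 2 `Cc1cc(C(=O)NCc2cccnc2)nn1Cc1cc(Cl)ccc1OCc1ccccc1` — > 3.7 (a limit of the assay)
compound 3 `Cc1cc(NC(=O)CC(C)(C)C)nn1Cc1cc(Cl)ccc1OCc1ccccc1` — > 3.7 (a limit of the assay)

In a physicochemical assay for lipophilicity, at pH 7.4 (a lower number here means a more polar compound, a higher number a more lipophilic compound), compound 1 gives 2.8. For compound 2 the read-out is only a limit, > 3.7. For compound 3 the read-out is likewise only a limit, > 3.7. Compound 3 therefore stands at the top of the measured range, at the limit of > 3.7 in this assay, at which 2 of the 3 values shown sit. The steps of a number at least 0.90 log units higher from compound 1 to compound 2 (beyond the scatter) and a number at least 0.90 log units higher from compound 1 to compound 3 (beyond the scatter) are both at least modest rises, while the step that the two limits leave unreadable from compound 2 to compound 3 cannot be read.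

Compound 4 `Cc1cc(NC(=O)c2ccccc2)nn1Cc1cc(Cl)ccc1OCc1ccccc1` differs from compound 3 by phenyl in place of neopentyl on a carbonyl carbon. Within the data shown here, none of the measured steps involves this exchange, so no direct guide exists. Compound 4 is therefore expected to remain near the limit, a step that the limit leaves unreadable from compound 3 to compound 4. The estimate for compound 4 is 3.9, in the range 3.3 to 4.6.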

Compound 4, distribution coefficient: > 3.7
Compound 4: a limit, no number; the forecaster's own chance of this, stated with the estimate: 60%; the middle value does not contradict the limit.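

In this assay compound 4 gives > 3.7, a limit of the assay and not a number. Benzamido in place of (3-fluorophenyl)carbamoyl on an aromatic carbon gives a number at least 0.90 log units higher from compound 1 to compound 4 (beyond the scatter), so phenyl on this carbonyl carbon, like neopentyl, leaves no measurable value. Compound 1 remains the only compound with a number: the limit of > 3.7 in this assay, at which 3 of the 4 values shown sit.

The steps among compound 2, compound 3 and compound 4 cannot be read, so phenyl and neopentyl cannot be ranked here. Going by these compounds, whether a carboxylic acid or an amine on the group at this carbonyl carbon would bring the reading within range remains open.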